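Phenyl replacing fluoroethyl on the ring-bearing chain

A few compounds are considered here, and "the series" means these few. Any claim that something is new, unique, unknown or untested is made for them only; others in the source may bear on it.

Three analogues share one core. Compound 1 `CCCCC1([C@H](O)/C=C/[C@H]2COC(=O)N2CCSc2nc(C(=O)O)cs2)CCC1` gives 220 nM in an assay on isolated protein for binding affinity to prostaglandin E2 receptor EP1 subtype (Homo sapiens); on this read-out lower numbers stand for stronger inhibition and higher numbers for weaker inhibition; compound 2 `CC(C)(C)CCC1([C@H](O)/C=C/[C@H]2COC(=O)N2CCSc2nc(C(=O)O)cs2)CCC1` gives 149 nM, and the step of a 1.5-fold lower number from compound 1 to compound 2 (0.17 log units; within the scatter) stays within the scatter. Compound 3 `O=C(O)c1csc(SCCN2C(=O)OC[C@@H]2/C=C/[C@@H](O)C2(CCCCF)CCC2)n1` gives 1080 nM, the highest number of the three, with a 4.9-fold higher number from compound 1 to compound 3 (0.69 log units; beyond the scatter) and a 7.2-fold higher number from compound 2 to compound 3 (0.86 log units; beyond the scatter). Compound 4 `O=C(O)c1csc(SCCN2C(=O)OC[C@@H]2/C=C/[C@@H](O)C2(CCc3ccccc3)CCC2)n1` is unmeasured; the change is phenyl in place of 2-fluoroethyl on a saturated chain carbon, two bonds along the chain from a saturated ring carbon. The two steps into compound 3 show that the fluorine-bearing chain sits well above the plain alkyl chains, and removing it here is expected to reverse that loss, so a 4.3-fold lower number from compound 3 to compound 4 (0.64 log units; beyond the scatter) is estimated. Compound 4 is therefore expected near 250 nM, within a range from 70 nM to 900 nM.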

Compound 4, inhibition constant: 802 nM
For compound 4 the middle estimate is 3.2-fold (0.51 log units) below the measured one, and the stated range covers the measured number.
By their numbers in this assay, from the lowest: compounds 2 and 1 (each within the scatter of the next); then compounds 4 and 3 (each within the scatter of the next).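

In this assay, phenyl does not restore what the plain alkyl chains give, since a 1.3-fold lower number from compound 3 to compound 4 (0.13 log units; within the scatter) leaves the two compounds level. Compound 4 stays apart from those chains, with a 3.6-fold higher number from compound 1 to compound 4 (0.56 log units; beyond the scatter) and a 5.4-fold higher number from compound 2 to compound 4 (0.73 log units; beyond the scatter) both lying beyond the scatter, so at this position the phenyl and 2-fluoroethyl ends read alike and neither matches ethyl or tert-butyl. No evidence given here accounts for this. The compounds shown leave open whether a cyclohexyl group in place of phenyl would return to the level of the alkyl chains, and how an amine at the chain end would read.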